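A Methoxy Step Repeated on a Second Core

This account rests on a few compounds, and the source may have more. Where it says the series, first, only, none or still open, it means among the compounds named here.

Four compounds from one series are followed here. Compound 1 `COc1ccccc1C(=O)c1sc2nc(-c3cccs3)ccc2c1N` gives 0.059 ug/mL in a functional assay on WI-38 VA13 cells (Homo sapiens) for cytotoxicity; a higher number here means that more compound is needed for the effect, a lower number that less compound is needed. Compound 2 `COc1ccc(OC)c(C(=O)c2sc3nc(-c4cccs4)ccc3c2N)c1` differs from compound 1 by methoxy in place of hydrogen on an aromatic carbon, and in this assay compound 2 gives 0.079 ug/mL. That change made a 1.3-fold higher number from compound 1 to compound 2 (0.13 log units; within the scatter).

Compound 3 `COc1ccccc1C(=O)c1oc2cc(-c3ccccc3)cc(O)c2c1C` is built on another core; the difference between the two cores is not broken down here. In this assay compound 3 gives 0.09 ug/mL. The values of compound 3 and compound 2 lie within the scatter of each other, and so do the values of compound 3 and compound 1, so no order among the three can be read from these numbers.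

Compound 4 `COc1ccc(OC)c(C(=O)c2oc3cc(-c4ccccc4)cc(O)c3c2C)c1` has not yet been measured in this assay. Going by the values given here, it differs from compound 3 by methoxy in place of hydrogen on an aromatic carbon, which is the same change as the one leading from compound 1 to compound 2, now carried out on the core of compound 3.

The step in this assay is expected to be a 1.2-fold higher number from compound 3 to compound 4 (0.09 log units; within the scatter), because on the other core the same change gave a 1.3-fold higher number from compound 1 to compound 2 (0.13 log units; within the scatter), a step that stayed within the scatter, and there is no measured case of this change on the core of compound 3 to say otherwise. Compound 4 is therefore estimated at 0.11 ug/mL, with a range from 0.05 ug/mL to 0.25 ug/mL.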

Compound 4, half-maximal effective concentration: 0.09 ug/mL
For compound 4 the middle estimate is 1.2-fold (0.09 log units) above the measured one; the range from low to high includes it.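

On the core of compound 3, methoxy in place of hydrogen gave, in this assay, no change at the digits printed from compound 3 to compound 4 (within the scatter). Set beside the same change on the core of compound 1, this step shows no difference that can be read between the two cores: the same change on two cores in this assay, a 1.3-fold higher number (0.13 log units; within the scatter) from compound 1 to compound 2 and no change at the digits printed (within the scatter) from compound 3 to compound 4, 1.3-fold (0.13 log units) apart, within the scatter of two such steps. Going by these compounds alone, with only two pairs, both inside the scatter, the result shows that this methoxy made no readable difference on either core in this one assay, but it does not show that the change would behave the same way on a further core or in any other measurement.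

The compounds shown carry only hydrogen or methoxy at this position, so they leave open whether an ethoxy group or a carboxylic acid in place of the same hydrogen would also give matching steps on the two cores. They also leave open whether a step beyond the scatter on one core would be repeated on the other, since neither pair here provides such a step to carry across.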